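Fluoro for Methoxy on the Shared Core

The compounds below may be only part of what the source reports. "The series", "measured", "known", "first", "only" and "open" are said of these compounds alone.

This account concerns three measured compounds and one not yet measured, all tested in an ADME assay on HEK-293T cells (Homo sapiens) for cytotoxicity, read by MTT assay, with a stated time of 48 h, in the absence of a further agent; a higher number here means a weaker inhibitor, a lower number a stronger inhibitor. Compound 1, `COc1ccc2[nH]cc(-c3nc(C(=O)Nc4cc(OC)c(OC)c(OC)c4)cs3)c2c1`, gives 8600 nM in this assay, the lowest of the two numbers available. Compound 3, `COc1ccc(NC(=O)c2csc(-c3c[nH]c4ccc(F)cc34)n2)cc1`, gives 12100 nM, which lies within the scatter of compound 1. Compound 2, `Cc1ccc(NC(=O)c2csc(-c3c[nH]c4ccccc34)n2)cc1`, gives > 100000 nM, a limit of the assay rather than a number (the limit of > 100000 nM in this assay, at which 1 of the 3 values shown sits). The unmeasured compound 4, `COc1cc(NC(=O)c2csc(-c3c[nH]c4ccc(F)cc34)n2)cc(OC)c1OC`, differs from compound 1 in one place: fluoro in place of methoxy on an aromatic carbon. Among the measured compounds shown here, no step between measured compounds of this kind is available, so no direction is fixed by the data. Given that compound 1 at 8600 nM and compound 3 at 12100 nM sit within the scatter of one another, compound 4 is expected to stay within the scatter of compound 1, with a step of a 1.0-fold higher number from compound 1 to compound 4 (0.02 log units; within the scatter). The estimate for compound 4 is 9000 nM, with a range from 4000 nM to 25000 nM.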

Compound 4, half-maximal inhibitory concentration: > 100000 nM
Compound 4: no number, only a limit (the forecaster's own chance of this, stated with the estimate: 5%); middle value at least 11-fold (1.04 log units) away from the limit.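

In this assay, among the compounds shown here, fluoro in place of methoxy on an aromatic carbon gives an at least 11-fold higher number from compound 1 to compound 4 (1.06 log units; beyond the scatter), the only step between measured compounds here, and it lies beyond the scatter. Compound 4 gives > 100000 nM, which is a limit of the assay and not a number. The position, meta to a fused ring and para to a fused ring, is therefore not indifferent to this change, as with the rest of compound 1 held, methoxy goes with a measured number and fluoro with a limit: the limit of > 100000 nM in this assay, at which 2 of the 4 values shown sit.

As far as these compounds go, how far compound 4 lies past that limit remains open. Also open, from the compounds shown here alone, is whether the step follows from the arrival of fluoro or the departure of methoxy; a chloro group or an amine at this position would help to separate the two.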